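Trimming the Amide Substituent: Expected Effect on Cell Toxicity

This account rests on a few compounds, and the source may have more. Where it says the series, first, only, none or still open, it means among the compounds named here.

Measured compounds:
- compound 1 `COc1ccc(-c2cnc(NC(=O)c3cccnc3)n2C)cc1`: > 100000 nM
- compound 2 `Cn1c(-c2ccc(F)cc2)cnc1NC(=O)c1ccc(F)cc1`: > 100000 nM

Of the compounds shown here, two have been tested in a toxicity assay on THP-1 cells (Homo sapiens) for inhibition; on this read-out higher numbers stand for lower toxicity in this test and lower numbers for higher toxicity in this test. Compound 1 gives > 100000 nM, which is a limit of the test and not a number. Compound 2 likewise gives > 100000 nM, again a limit rather than a measured value. Both results therefore sit at the limit of > 100000 nM in this assay, at which 2 of the 2 values shown sit, so compound 1 cannot be ranked against compound 2 on these numbers; both are simply beyond the reach of the test.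

Compound 3 `COc1ccc(-c2cnc(NC(C)=O)n2C)cc1` has not yet been measured. It differs from compound 1 in one place: methyl in place of pyridin-3-yl on a carbonyl carbon. Among the compounds with values here, no step between measured compounds is available to calibrate this change. Since compound 1 showed no toxicity up to the limit, compound 3 is expected to behave the same way, and the step from compound 1 to compound 3 is estimated as a step that the limit leaves unreadable from compound 1 to compound 3, that is, no shift beyond the scatter in this assay. Compound 3 is accordingly expected to give about 150000 nM in this assay, between 50000 nM and 500000 nM, most likely reported again only as a limit.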

Compound 3, half-maximal cytotoxic concentration: > 100000 nM
Compound 3: no number, only a limit; the forecaster's own chance of this, stated with the estimate: 80%; the middle value is on the limit's open side.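

Within the data shown here, compound 3 also ends at a limit and not at a number, so, as with compound 1, no step from compound 1 to compound 3 can be read: the limit of > 100000 nM in this assay, at which 3 of the 3 values shown sit. The compounds shown leave open how the amide substituent bears on the read-out in this assay, since none of them gives a value inside the range of the test.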